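This account rests on a few compounds, and the source may have more. Where it says the series, first, only, none or still open, it means among the compounds named here.

Compound 2 `Cc1ccc(CN2C(=O)S/C(=C\c3ccc(F)cc3)C2=O)cc1` is tested in a functional assay on the whole organism (plasma) with Mus musculus as the target, with a stated time of 15 days, at a dose of 30 mg/kg by the oral route (on this read-out lower numbers stand for a weaker effect and higher numbers for a stronger effect at the one dose given), where compound 2 gives 13.5%. Among the three compounds with a number on this read-out, compound 2 stands second highest. Its nearest neighbour is compound 1 `Cc1ccc(CN2C(=O)S/C(=C\c3ccc([N+](=O)[O-])cc3)C2=O)cc1`, and compound 1 gives 11.4%, so the two lie within the usual scatter of each other. Furthest away is compound 3 `COc1ccc(/C=C2\SC(=O)N(Cc3ccc(C)cc3)C2=O)c(OC)c1`, and compound 3 gives 34.6%, a gap that goes beyond the scatter.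

Compound 4 `Cc1ccc(CN2C(=O)S/C(=C\c3ccc(N(C)C)cc3)C2=O)cc1` has not yet been measured. It differs from compound 2 in one place: dimethylamino in place of fluoro on an aromatic carbon. Among the compounds with values here, the only measured step that bears on a swap at this same spot is the exchange of a nitro group for a fluoro group, a number 2.1 percentage points higher from compound 1 to compound 2 (within the scatter), which stayed within the scatter. Within the data shown here, no measured step shows what a dimethylamino group does here, and compound 3 carries two methoxy groups rather than a single one, so no single-place step connects it to compound 2; its higher number is at most a hint.

What is expected is therefore only a small step, a number 4.5 percentage points higher from compound 2 to compound 4 (within the scatter), most likely not beyond the scatter, with a slight lean upward. Compound 4 is estimated to give 18%, within a range from 6% to 32%.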

Compound 4, a percentage reported as activity, at one dose (the size of the read-out at that dose, not a potency): 40.8%
Estimate against measurement, compound 4: 22.8 percentage points below; the whole stated range lies below it.
By their numbers in this assay, from the lowest: compounds 1 and 2 (each within the scatter of the next); then compounds 3 and 4 (each within the scatter of the next).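

In this assay, within the data shown here, the only earlier swap at this spot, a number 2.1 percentage points higher from compound 1 to compound 2 (within the scatter), left open whether the group there matters at all, and the dimethylamino group answers that, with a number 27.3 percentage points higher from compound 2 to compound 4 (beyond the scatter) and with a number 29.4 percentage points higher from compound 1 to compound 4 (beyond the scatter) as well. The position on the aromatic carbon, para to a large group, is therefore not indifferent: a change here alone can move the number well beyond the scatter, which the nitro and fluoro compounds could not show because their values sit within the scatter of each other. Nothing measured on these compounds explains why the dimethylamino group has this effect.

The compounds shown leave open whether this step belongs to the dimethylamino group in particular or would also appear with a plain amine, a methylamino group or a diethylamino group at the same spot. They also leave open whether the step would keep its size at other doses, since a number at one dose describes the size of the effect at that dose and is not a potency.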